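Chloro in place of hydrogen, second core

The source may hold more compounds than are shown below. What is called first, only, known or untested is meant among the compounds shown, and "the series" means these compounds.

Measured so far:
compound 1, `COc1ccc(-n2nc(Sc3ccc(Cl)cc3)cc(CC[C@@H](C)NC(=O)[C@H]3CNCC[C@@H]3c3ccc(Cl)cc3)c2=O)cc1`, 2.4 nM in an assay on CHO cells for binding affinity to Melanocortin receptor 4 (Homo sapiens); a lower number here means a stronger inhibitor, a higher number a weaker inhibitor
compound 2, `COc1ccc(-n2nc(Sc3ccc(Cl)cc3)cc(CC[C@@H](C)NC(=O)[C@H]3CNCC[C@@H]3c3ccc(Cl)cc3Cl)c2=O)cc1`, 3.2 nM in this assay
compound 3, `COc1ccc(-n2nc(Sc3ccc(Cl)cc3)cc(CC[C@@H](C)NC(=O)[C@H]3CCNC[C@@H]3c3ccc(Cl)cc3)c2=O)cc1`, 58 nM in this assay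

Compound 1 and compound 2 share a core and differ by chloro in place of hydrogen on an aromatic carbon. The step this change made is a 1.3-fold higher number from compound 1 to compound 2 (0.12 log units; within the scatter).

Compound 3 has the same atoms as compound 1, joined differently; the difference between the two cores is not broken down here. In this assay compound 3 gives 58 nM, against 2.4 nM for compound 1 and 3.2 nM for compound 2, so the core of compound 3 carries the highest number of the three.

Compound 4, `COc1ccc(-n2nc(Sc3ccc(Cl)cc3)cc(CC[C@@H](C)NC(=O)[C@H]3CCNC[C@@H]3c3ccc(Cl)cc3Cl)c2=O)cc1`, is not yet measured. It differs from compound 3 by chloro in place of hydrogen on an aromatic carbon, the same change as that from compound 1 to compound 2, at the same kind of place. Since that change gave a 1.3-fold higher number from compound 1 to compound 2 (0.12 log units; within the scatter), the step for compound 4 is expected to be about a 1.3-fold higher number from compound 3 to compound 4 (0.11 log units; within the scatter), again within the scatter. Compound 4 is therefore estimated at 75 nM, between 40 nM and 140 nM, on a single precedent only.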

Compound 4, half-maximal inhibitory concentration: 36 nM
Compound 4: the middle estimate sits 2.1-fold (0.32 log units) above what was measured; the whole stated range lies above it.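

In this assay the change from 4-chlorophenyl to 2,4-dichlorophenyl on the second core gives a 1.6-fold lower number from compound 3 to compound 4 (0.21 log units; within the scatter). Set beside the same change on the first core, the two steps cannot be told apart: the same change on two cores in this assay, a 1.3-fold higher number (0.12 log units; within the scatter) from compound 1 to compound 2 and a 1.6-fold lower number (0.21 log units; within the scatter) from compound 3 to compound 4, 2.1-fold (0.33 log units) apart, within the scatter of two such steps. On these two cores the added chloro therefore gives no readable step in either direction, which shows that the change is tolerated on both but rests on two pairs only and does not show that it would behave the same way on any other core.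

Open, from the compounds shown here alone, is how a group other than chloro would behave at the same place on the ring, for example fluoro, methyl or a nitrile. The methoxy group is also shared by all four compounds, so what an ethoxy or hydroxyl group would do there remains an open question.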